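The compounds below may be only part of what the source reports. "The series", "measured", "known", "first", "only" and "open" are said of these compounds alone.

Measured so far in a functional assay on NCI-H460 cells (Homo sapiens) for inhibition, read by sulforhodamine B assay, with a stated time of 48 h; on this read-out higher numbers stand for weaker inhibition of growth and lower numbers for stronger inhibition of growth:
compound 1 `Nc1cc(N)c2nc(-c3ccccc3)c(Sc3ccc(F)cc3)nc2c1`: 21900 nM
compound 2 `COc1cc(CNc2nc3cc(N)cc(N)c3nc2-c2ccccc2)cc(OC)c1OC`: 1510 nM
compound 3 `CCOC(=O)[C@H](CCC(=O)O)NC(=O)c1ccc(CNc2nc3cc(N)cc(N)c3nc2-c2ccccc2)cc1`: 31600 nM

Compound 1 stands second highest of the three numbers in this assay. Its nearest neighbour is compound 3, whose number is somewhat higher but within the scatter, so no order between compound 1 and compound 3 can be read. Compound 2 stands far lower, beyond the scatter, so of the three shown compound 2 gives the stronger inhibition of growth.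

The step considered runs from compound 1 to compound 4 `Nc1cc(N)c2nc(-c3ccccc3)c(NCc3ccc(F)cc3)nc2c1`: (4-fluorobenzyl)amino in place of (4-fluorophenyl)sulfanyl on an aromatic carbon. Among the measured compounds shown here, no measured pair shows this change alone. Compound 2 and compound 3, which share the amino linkage of compound 4 rather than the sulfanyl linkage of compound 1, lie on either side of compound 1 in this assay, so the linkage by itself fixes no direction. Some movement toward lower numbers seems more likely than not, but a step within the scatter cannot be excluded. Compound 4 is therefore estimated at 6000 nM in this assay, with a range of 1200 nM to 30000 nM. The expected step of a 3.7-fold lower number from compound 1 to compound 4 (0.56 log units; beyond the scatter) is thus a modest lowering, uncertain in size.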

Compound 4, concentration for 50% growth inhibition: 4070 nM
The estimate for compound 4 lay 1.5-fold (0.17 log units) above the measured number, and the stated range covers the measured number.
By their numbers in this assay, from the lowest: compound 2; then compound 4; then compounds 1 and 3 (each within the scatter of the next).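

In this assay this position gives its first direct reading, with a 5.4-fold lower number from compound 1 to compound 4 (0.73 log units; beyond the scatter) for (4-fluorobenzyl)amino in place of (4-fluorophenyl)sulfanyl on the aromatic carbon next to the ring nitrogen and ortho to a phenyl group. The step is a modest lowering beyond the scatter, so the group at this position does change the read-out on the shared core, and it changes the linking atom, the chain length and the hydrogen-bond donor count together. No measured evidence bears on the origin of this step.

The compounds shown leave open which part of the change carries the step, a question that a phenylamino or a benzylsulfanyl group at this position would address. They also leave open whether the step holds with an unsubstituted benzylamino group or a longer chain such as phenethylamino.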